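This account rests on a few compounds, and the source may have more. Where it says the series, first, only, none or still open, it means among the compounds named here.

Working notes on the series in a functional assay on a cell-free system (plasma, Homo sapiens), with a stated time of 3 min; a higher number here means a weaker inhibitor, a lower number a stronger inhibitor. Compound 1 (`O=C(NCc1cc(Cl)ccc1-n1cnnn1)[C@@H]1C[C@@H]2C[C@@H]2N1C(=O)[C@H](O)c1cccc(Cl)c1`) gives 1000 nM, compound 2 (`CC(C)(C)[C@@H](O)C(=O)N1C[C@H]2C[C@H]2[C@H]1C(=O)NCc1cc(Cl)ccc1-n1cnnn1`) gives 1200 nM and compound 3 (`O=C(NCc1cc(Cl)ccc1-n1cnnn1)[C@@H]1[C@H]2C[C@H]2CN1C(=O)[C@H](O)Cn1cccn1`) gives 1800 nM. All three lie within the scatter of one another, so compound 1 stands level with the other two.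

Compound 4 (`O=C(NCc1cc(Cl)ccc1-n1cnnn1)[C@@H]1C[C@@H]2C[C@@H]2N1C(=O)[C@H](O)c1ccccc1F`) is still unmeasured. Its change from compound 1 is 2-fluorophenyl in place of 3-chlorophenyl on a saturated chain carbon bound to a carbonyl carbon and an oxygen on a saturated carbon.

Going by the values given here, no measured pair differs in one place only, so the data hold no direct precedent for this step. Compound 2 at 1200 nM and compound 3 at 1800 nM differ from compound 1 in more than one place and still stay within the scatter of it. A step no larger than the scatter in this assay is therefore expected, with a slight lean toward a higher number. The expected step is a 1.5-fold higher number from compound 1 to compound 4 (0.18 log units; within the scatter). For compound 4 the estimated value is 1500 nM, with an expected range of 600 nM to 3500 nM.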

Compound 4, half-maximal inhibitory concentration: 770 nM
Estimate against measurement, compound 4: 1.9-fold (0.29 log units) above, and the stated range covers the measured number.
By their numbers in this assay, from the lowest: compounds 4, 1, 2 and 3 (each within the scatter of the next, the first and the last beyond it).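

In this assay, 2-fluorophenyl in place of 3-chlorophenyl on a saturated chain carbon bound to a carbonyl carbon and an oxygen on a saturated carbon gives a 1.3-fold lower number from compound 1 to compound 4 (0.11 log units; within the scatter). Going by these compounds alone, this is the first pair that differs in one place only, and it shows that this position tolerates an exchange of both the halogen and its location on the phenyl ring without a step beyond the scatter. No measured evidence on the cause of this result is available.

The pair changes the halogen and its location together, so the contribution of each remains unresolved, and 2-chlorophenyl or 3-fluorophenyl would be needed to separate them. Also open, on these data alone, is whether an unsubstituted phenyl, or a phenyl carrying an aminomethyl group or a carboxylic acid, would move the number beyond the scatter at this position.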